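Fluoro to methyl on the aryl ether of compound 1

The source may hold more compounds than are shown below. What is called first, only, known or untested is meant among the compounds shown, and "the series" means these compounds.

Measured so far:
compound 1 `C[C@@H](Oc1cc2oc(=O)n(CCC(=O)O)c2cc1Cl)c1ccc(F)cn1`: 25.1 nM
compound 2 `Cc1ccc([C@@H](C)Oc2cc3onc(CCC(=O)O)c3cc2Cl)nn1`: 3.16 nM
compound 3 `O=C(O)CCn1c(=O)oc2cc(OCC3CC3)c(Cl)cc21`: 1580 nM

The three compounds were run in an assay on HEK293 cells for inhibition of kynurenine 3-monooxygenase (Homo sapiens), read by LC-MS, with a stated time of 20 h; a higher number here means a weaker inhibitor, a lower number a stronger inhibitor. Compound 1 stands second highest of the three numbers, with 25.1 nM. Its nearest neighbour is compound 2, whose 3.16 nM lies beyond the scatter on the lower side; compound 3, with 1580 nM, lies furthest away and beyond the scatter on the higher side. Within the data shown here, no pair of these three differs in only one place, so no single step can be read off between them; the gaps are simply what the values show.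

Compound 4 `Cc1ccc([C@@H](C)Oc2cc3oc(=O)n(CCC(=O)O)c3cc2Cl)nc1` is not yet measured. It differs from compound 1 by methyl in place of fluoro on an aromatic carbon, the change being methyl in place of fluoro on an aromatic carbon; cut one bond further out, 5-fluoropyridin-2-yl becomes 5-methylpyridin-2-yl. The group that leaves and the one that enters are each a single heavy atom with no donor or acceptor, so the change is small on paper.

Compound 4 is expected to land near compound 1, with a step from compound 1 to compound 4 of a 1.8-fold lower number from compound 1 to compound 4 (0.25 log units; within the scatter), a modest lowering that may not exceed the scatter. The estimate for compound 4 is 14 nM, within a range from 4 nM to 45 nM.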

Compound 4, half-maximal inhibitory concentration: 6.31 nM
Estimate against measurement, compound 4: 2.2-fold (0.35 log units) above; low and high end bracket the measured number.
By their numbers in this assay, from the lowest: compounds 2 and 4 (each within the scatter of the next); then compound 1; then compound 3.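

In this assay, among these compounds, the change from 5-fluoropyridin-2-yl to 5-methylpyridin-2-yl gives a 4.0-fold lower number from compound 1 to compound 4 (0.60 log units; beyond the scatter), the first step that can be read at a single place. This position, on an aromatic carbon two atoms from the ring nitrogen and para to a large group, therefore responds to the exchange of one heavy atom for another, even though neither the fluoro nor the methyl group counts a hydrogen-bond donor or acceptor. No measurement at hand bears on what lies behind the step.

On these data alone, it remains open whether the response at this position is particular to methyl, or whether an ethyl, a methoxy or a nitrile in the same place would give a lower or higher number than compound 4 does at 6.31 nM. Compound 2 differs from compound 4 in more than one place, so no step can be read between them, and whether the fluoro-to-methyl change carries the same size on any other core is also unsettled.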